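The compounds below may be only part of what the source reports. "The series", "measured", "known", "first", "only" and "open" are said of these compounds alone.

Series notes. Compound 1 `CCCCCCc1ccc(NC(=O)N[C@@H](C)c2ccccc2)cc1` and compound 2 `C[C@H](NC(=O)Nc1ccc(F)cc1)c1ccccc1` differ by fluoro in place of hexyl on an aromatic carbon. In an ADME assay on the whole organism with Oryza sativa as the target, tested at 1 uM (on this read-out lower numbers stand for a stronger effect and higher numbers for a weaker effect at the one concentration tested), compound 1 gives 100% and compound 2 gives 97%; the step is a number 3 percentage points lower from compound 1 to compound 2 (within the scatter). For the measured compounds named here, compound 2 thus sits together with compound 1, the only other number measured, inside the usual scatter. Compound 3 `C[C@H](NC(=O)Nc1ccc(F)c(F)c1)c1ccccc1` differs from compound 2 by fluoro in place of hydrogen on an aromatic carbon. Going by the values given here, no measured step covers this change; the one available step, a number 3 percentage points lower from compound 1 to compound 2 (within the scatter), stayed within the scatter. In this assay no step beyond the scatter is therefore expected, no change at the digits printed from compound 2 to compound 3 (within the scatter). Compound 3 is estimated at 97%, between 85% and 100%.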

Compound 3, a percentage reported as activity, at one concentration (the size of the read-out at that concentration, not a potency): 100%
Compound 3: middle estimate off by 3 percentage points, on the low side, within the range that was stated.
By their numbers in this assay, from the lowest: compounds 2, 1 and 3 (each within the scatter of the next).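

In this assay, fluoro in place of hydrogen, ortho to a fluoro group and meta to a large group, gives a number 3 percentage points higher from compound 2 to compound 3 (within the scatter) and so leaves the number inside the scatter. This is the second single-place change on the ring that stays within the scatter, now at a hydrogen rather than at the hexyl group. Nothing available explains this result.
Open, from the compounds shown here alone, is whether an amine, a methoxy or a carboxylic acid at this position would give a step beyond the scatter. Also open, going by these compounds, is whether any group on this ring can do so.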